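The source may report more compounds than this note shows. Statements on the series, on what has been measured and on what is new or still open speak of the compounds shown alone.

Measured so far:
- compound 1 `Cn1nc2c(=O)n(CC3(O)CCN(Cc4ccc(-c5ccncc5)cc4Cl)CC3)cnc2c1-c1ccc(CN)cc1`: 257 nM
- compound 2 `Cn1nc2c(=O)n(CC3(O)CCN(Cc4ccc(-c5ccsc5Cl)cc4Cl)CC3)cnc2c1-c1ccc(CN)cc1`: 453 nM
- compound 3 `Cn1nc2c(=O)n(CC3(O)CCN(Cc4ccc(-c5ccco5)cc4Cl)CC3)cnc2c1-c1ccc(CNC=O)cc1`: 20.9 nM

In an assay on isolated protein for inhibition of ubiquitin carboxyl-terminal hydrolase 7 (Homo sapiens), with stated times of 30 min and 2 h (on this read-out lower numbers stand for stronger inhibition and higher numbers for weaker inhibition), compound 2 gives the highest of the three numbers. Within the data shown here, compound 1 gives a number within the scatter of compound 2, and the one step between them, a 1.8-fold higher number from compound 1 to compound 2 (0.25 log units; within the scatter), is the only single-point comparison on hand. Compound 3 gives a far lower number than compound 2, but it differs from compound 2 in two places, so its reading cannot be tied to either change alone.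

Compound 4 `Cn1nc2c(=O)n(CC3(O)CCN(Cc4ccc(-n5cccn5)cc4Cl)CC3)cnc2c1-c1ccc(CN)cc1` is not yet measured. It carries 1H-pyrazol-1-yl in place of 2-chlorothiophen-3-yl on an aromatic carbon. Among the measured compounds shown here, the single step that bears on this position, a 1.8-fold higher number from compound 1 to compound 2 (0.25 log units; within the scatter), shows that swapping one aromatic group for another there left the number within the scatter. On that basis the step of a 1.3-fold lower number from compound 2 to compound 4 (0.11 log units; within the scatter) is expected to stay within the scatter as well, with no clear direction; compound 4 is therefore estimated at 350 nM, with a range of 150 nM to 800 nM.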

Compound 4, half-maximal inhibitory concentration: 233 nM
Compound 4: the middle estimate sits 1.5-fold (0.18 log units) above what was measured; the range from low to high includes it.
By their numbers in this assay, from the lowest: compound 3; then compounds 4, 1 and 2 (each within the scatter of the next).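

In this assay, a 1.9-fold lower number from compound 2 to compound 4 (0.29 log units; within the scatter) and a 1.1-fold lower number from compound 1 to compound 4 (0.04 log units; within the scatter), so 1H-pyrazol-1-yl, 2-chlorothiophen-3-yl and pyridin-4-yl can be read as one level at this aromatic carbon, para to a large group and meta to a chloro group. Among these compounds, the earlier single step covered only two aryl groups; the new compound extends the flat reading to a five-membered aromatic ring with 2 hetero atoms, carrying neither the sulfur nor the chlorine of 2-chlorothiophen-3-yl. Nothing on hand accounts for this flat reading.

Going by these compounds, whether a non-aromatic group here, such as a morpholine or a carboxylic acid, would read the same remains open. Also open, on these data alone, is how much of the far lower number of compound 3 (20.9 nM) belongs to its furan-2-yl group and how much to its formamide in place of the primary amine.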